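Removing a Ring Fluorine: Mouse Microsomal Stability

The source may report more compounds than this note shows. Statements on the series, on what has been measured and on what is new or still open speak of the compounds shown alone.

Compound 1, `O=C(O)c1ccc(-n2cc(C(=O)c3c(Cl)cccc3Cl)c3cccnc32)cc1`: 100%
Compound 2, `O=C(O)c1ccc(-n2cc(C(=O)c3c(Cl)cccc3C(F)(F)F)c3cccnc32)c(F)c1`: 87%

In an ADME assay on microsomes from liver (Mus musculus) for metabolic stability, read by LC-MS, using NADPH, with stated times of 5 min and 30 min, tested at 1 uM (a higher number here means that more of the compound is left, a lower number that less of the compound is left), compound 2 stands lowest of the two measured compounds; its nearest neighbour, compound 1, sits higher by a gap beyond the scatter. Compound 3, `O=C(O)c1ccc(-n2cc(C(=O)c3c(Cl)cccc3C(F)(F)F)c3cccnc32)cc1`, differs from compound 2 by hydrogen in place of fluoro on an aromatic carbon. Among the compounds with values here, no measured pair shows this change on its own, so the step from compound 2 to compound 3 is expected to stay within the scatter, if anything slightly upward; a number 3 percentage points higher from compound 2 to compound 3 (within the scatter) is the step this expectation means. Compound 3 is therefore estimated at 90%, within a range from 76% to 100%.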

Compound 3, percent of the compound remaining: 84%
Compound 3: the middle estimate sits 6 percentage points above what was measured; measured number inside the range.
By their numbers in this assay, from the lowest: compounds 3 and 2 (each within the scatter of the next); then compound 1.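

In this assay, hydrogen in place of fluoro on this aromatic carbon, ortho to a large group and meta to a carboxy group, gives a step too small to count (a number 3 percentage points lower from compound 2 to compound 3 (within the scatter)), so the fluorine shows no clear effect on the number here. Compound 3 also isolates trifluoromethyl in place of chloro on an aromatic carbon, and that change gives a real step (a number 16 percentage points lower from compound 1 to compound 3 (beyond the scatter)). Nothing here gives a reason for either step.

Going by these compounds, whether a methoxy group or an amine at the fluorine's position would hold the number remains open. So does whether a methyl group in place of the trifluoromethyl would do so.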